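Cyclopropyl in place of 4-fluorophenyl: compound 3

The source may hold more compounds than are shown below. What is called first, only, known or untested is meant among the compounds shown, and "the series" means these compounds.

Measured so far:
compound 1 `Cc1nc(NC(=O)Cn2nnc(-c3ccccc3)n2)n(-c2ccccc2)n1`: "not active" (no number reported)
compound 2 `Cc1cc(NC(=O)Cn2nnc(-c3ccc(F)cc3)n2)n(C2CCCCC2)n1`: 92%

In an assay on HEK293 cells for activation of Kir3.1/Kir3.2 (Homo sapiens), read by thallium flux (a higher number here means a larger maximal response, a lower number a smaller maximal response), compound 1 gives "not active" (no number reported) and no number. In this assay, among the measured compounds shown here, compound 2 gives 92%, the only numerical value so far; compound 1 stands beside it as the one entry without a number, so compound 2 alone sets the reference for the maximal response. Compound 3 `Cc1cc(NC(=O)Cn2nnc(C3CC3)n2)n(C2CCCCC2)n1` keeps the core of compound 2 and differs in one place: cyclopropyl in place of 4-fluorophenyl on an aromatic carbon. For the measured compounds named here, no measured pair shows what such a change does in this assay; the group that leaves carries one six-membered aromatic ring, the group that enters one three-membered non-aromatic ring. As an expectation only, a step down beyond the usual scatter is anticipated, a number 32 percentage points lower from compound 2 to compound 3 (beyond the scatter). Compound 3 is estimated at 60%, within a range from 20% to 95%.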

Compound 3, largest response reached (Emax), in percent of the reference or control that the assay uses: > 68%
Compound 3 gave a limit, no number (the forecaster's own chance of this, stated with the estimate: 25%); middle value at least 8 percentage points from the limit.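

In this assay compound 3 gives > 68%, a limit and not a number. Among the compounds shown here, no step from compound 2 to compound 3 can be read from it. The compounds shown leave open what cyclopropyl in place of 4-fluorophenyl does to the maximal response.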